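Nitro for fluoro on the amide-linked phenyl ring

The compounds below may be only part of what the source reports. "The series", "measured", "known", "first", "only" and "open" are said of these compounds alone.

The series shares one core, carried by compound 1 `O=C(CSc1nc(Nc2ccccc2)c2ccccc2n1)Nc1cccc(F)c1`, compound 2 `O=C(CSc1nc(Nc2ccccc2)c2ccccc2n1)Nc1cccc([N+](=O)[O-])c1` and compound 3 `O=C(CSc1nc(Nc2ccccc2)c2ccccc2n1)Nc1ccc(F)cc1`. In a functional assay on MGC-803 cells (Homo sapiens) for inhibition, read by MTT assay, with a stated time of 72 h (on this read-out lower numbers stand for stronger inhibition and higher numbers for weaker inhibition), compound 1 gives 12700 nM and compound 2 gives 28100 nM. Compound 3 reaches only the limit of this assay, > 50000 nM, so no number is known for it. Among the three, compound 3 thus stands at the weak end of what is shown, resting on (the limit of > 50000 nM in this assay, at which 1 of the 3 values shown sits). The step to compound 4 `O=C(CSc1nc(Nc2ccccc2)c2ccccc2n1)Nc1ccc([N+](=O)[O-])cc1` is nitro in place of fluoro on an aromatic carbon. The measured step that bears on it most directly is the same exchange on the 3-fluorophenyl ring, a 2.2-fold higher number from compound 1 to compound 2 (0.34 log units; beyond the scatter), which weakened inhibition modestly. The change of substitution pattern itself, an at least 3.9-fold higher number from compound 1 to compound 3 (0.59 log units; beyond the scatter), already moved the number to the limit, and an at least 1.7-fold higher number from compound 2 to compound 3 (0.25 log units; that floor lies within the scatter) gives only a floor that lies within the scatter. On this basis the nitro compound is expected to sit at or beyond the limit again, with a number no lower than that of compound 3 and most likely none reported at all. Compound 4 is therefore estimated at 110000 nM, with a range from 45000 nM to 300000 nM. The step this estimate implies is expected to be a step that the limit leaves unreadable from compound 3 to compound 4 in this assay.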

Compound 4, half-maximal inhibitory concentration: > 50000 nM
Compound 4: only a limit was reported; the forecaster's own chance of this, stated with the estimate: 85%; the middle value does not contradict the limit.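

Compound 4, with nitro on the aromatic carbon para to a large group, gives > 50000 nM in this assay, and this is a limit of the assay, not a number. The exchange of the 3-fluorophenyl group for 4-nitrophenyl gives an at least 3.9-fold higher number from compound 1 to compound 4 (0.59 log units; beyond the scatter), whereas the shift of nitro alone, with 4-nitrophenyl in place of 3-nitrophenyl, gives only an at least 1.7-fold higher number from compound 2 to compound 4 (0.25 log units; that floor lies within the scatter). On the ring carrying the group para to the amide-type nitrogen, the size of the nitro-for-fluoro exchange cannot be read, unlike the same exchange on the 3-fluorophenyl ring, because both compounds rest on the same ceiling: the limit of > 50000 nM in this assay, at which 2 of the 4 values shown sit.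

Going by these compounds, whether any group on this ring carbon brings a number back under the limit stays open, for example an amine, a methoxy group or a carboxylic acid in place of the nitro. Also open is whether the gap between the 3-fluorophenyl and 4-fluorophenyl compounds would hold for chloro or methyl, since only fluoro and nitro are shown on this ring.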